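Chloro to Bromo: One Halogen Swap on Compound 2

This account rests on a few compounds, and the source may have more. Where it says the series, first, only, none or still open, it means among the compounds named here.

Measured so far:
compound 1, `CCN(CC)CN1C(=O)/C(=N\c2nc3ccc(C)cc3s2)c2ccccc21`, gives 20400 nM
compound 2, `O=C1C(=O)N(CN(c2ccccc2)c2ccccc2)c2cccc(Cl)c21`, gives 77200 nM

Both numbers come from an ADME assay on MCF-10A cells (Homo sapiens) for cytotoxicity, read by sulforhodamine B assay, with a stated time of 48 h; a higher number here means a weaker inhibitor of growth, a lower number a stronger inhibitor of growth. Of the two, compound 2 stands at the higher value, and compound 1 sits at a lower one, a gap that lies beyond the usual scatter of this assay. The two compounds share no single point of difference, so the gap says nothing about any one group.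

Compound 3, `O=C1C(=O)N(CN(c2ccccc2)c2ccccc2)c2cccc(Br)c21`, is the next compound to be measured in this assay. It differs from compound 2 in one place: bromo in place of chloro on an aromatic carbon. Such a swap of one halogen for the next is a small change in the structure, and on this basis the step from compound 2 to compound 3 is expected to stay within the scatter, with no clear direction.

Compound 3 is estimated at 65000 nM, within a range from 25000 nM to 160000 nM, which means an expected step of a 1.2-fold lower number from compound 2 to compound 3 (0.07 log units; within the scatter).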

Compound 3, concentration for 50% growth inhibition: 85800 nM
The estimate for compound 3 lay 1.3-fold (0.12 log units) below the measured number, and the stated range covers the measured number.
By their numbers in this assay, from the lowest: compound 1; then compounds 2 and 3 (each within the scatter of the next).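

Among these compounds, this is the first step that can be read at a single place, since compound 1 and compound 2 differ in more than one. In this assay, bromo in place of chloro on an aromatic carbon gives a 1.1-fold higher number from compound 2 to compound 3 (0.05 log units; within the scatter), so at this place the two halogens cannot be told apart by growth inhibition in these cells. Nothing measured here offers an explanation for this result.

Going by these compounds, the step compares only two halogens, so it remains open whether an amine, a methoxy group or a nitrile at this same place would shift the number beyond the scatter. On these data alone, it is also open whether the same halogen swap would give a similar result on an aromatic carbon elsewhere in the shared core.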